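A few compounds are considered here, and "the series" means these few. Any claim that something is new, unique, unknown or untested is made for them only; others in the source may bear on it.

Compound 3 `CCCCCCCCCCCCCCNC(=O)[C@@H](NC(=O)c1ccccc1)[C@@H](C)O` stands second highest of the three numbers in a functional assay on MCF7 cells (Homo sapiens) for cytotoxicity, read by MTT assay, with a stated time of 48 h (on this read-out higher numbers stand for weaker inhibition and lower numbers for stronger inhibition), where compound 3 gives 24800 nM. Its nearest neighbour is compound 1 `CCCCCCCCCCCCCCNC(=O)[C@@H](N)[C@@H](C)O`, which in this assay gives 10700 nM; the furthest is compound 2 `CCCCCCCCCCCCNC(=O)[C@@H](NC(=O)c1ccco1)[C@@H](C)O`, which gives 67500 nM. Compound 4 `CCCCCCCCCCCCCCNC(=O)[C@@H](NC(=O)c1ccco1)[C@@H](C)O` has not yet been measured and differs from compound 3 by furan-2-yl in place of phenyl on a carbonyl carbon. For the measured compounds named here, no measured step tests this exact exchange. Going by the values given here, the only single-point step available, a 2.3-fold higher number from compound 1 to compound 3 (0.37 log units; beyond the scatter), concerns the introduction of the benzoyl group rather than its replacement, so it bears on the change only indirectly. Among the compounds with values here, compound 2 carries the same (furan-2-yl)carbonyl group as compound 4 but a shorter chain, and its value shows only that a compound with this group can give a clearly higher number than compound 3. On this basis a modest rise in the number is expected: a 1.6-fold higher number from compound 3 to compound 4 (0.21 log units; within the scatter). Compound 4 is expected to give 40000 nM in this assay, within a range from 15000 nM to 100000 nM.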

Compound 4, half-maximal inhibitory concentration: 105000 nM
Compound 4: middle estimate off by 2.6-fold (0.42 log units), on the low side; the whole stated range lies below it.
By their numbers in this assay, from the lowest: compound 1; then compound 3; then compounds 2 and 4 (each within the scatter of the next).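

In this assay the exchange on the carbonyl carbon is now tested directly: furan-2-yl in place of phenyl gives a 4.2-fold higher number from compound 3 to compound 4 (0.63 log units; beyond the scatter), so the two rings are not interchangeable at this place. Placing (furan-2-yl)carbonyl on the amine nitrogen gives a 9.8-fold higher number from compound 1 to compound 4 (0.99 log units; beyond the scatter), the same direction as the benzoyl step, so both acyl groups read weaker than the free amine. The ethyl difference far along the chain gives a 1.6-fold higher number from compound 2 to compound 4 (0.19 log units; within the scatter), which lies within the scatter and does not separate the two compounds with this acyl group in place, and nothing measured here accounts for these steps.

Whether the ring oxygen or the ring size matters stays open, since a thiophen-2-yl or pyridyl carbonyl group does not stand among these compounds. Also open, from the compounds shown here alone, is how a longer chain, or an acyl group carrying an amine or a carboxylic acid, would read.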